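The source may report more compounds than this note shows. Statements on the series, on what has been measured and on what is new or still open speak of the compounds shown alone.

Measured compounds:
compound 1, `CCCCc1cc(C(C)=O)c(O)cc1OCCCCC#N`: 41%
compound 2, `C=CCc1cc(C(C)=O)c(O)cc1OCCCC#N`: 47%

Of the compounds shown here, two have been measured in an assay on isolated protein for inhibition of leukotriene B4 receptor 1 (Homo sapiens), tested at 10 uM; on this read-out higher numbers stand for more inhibition at the one concentration tested (going by the name of the read-out) and lower numbers for less inhibition. Compound 2 gives 47%, the highest of the two numbers, and compound 1 gives 41%, which sits within the scatter of that figure, so the two cannot be ordered. Compound 3, `C=CCc1cc(C(C)=O)c(O)cc1OCCCCC#N`, has not been measured yet. It differs from compound 2 in one place: cyanomethyl in place of cyano on a saturated chain carbon, three bonds along the chain from an oxygen on an aromatic ring. For the measured compounds named here, with only two compounds in hand and no step between them, nothing points to a shift beyond the scatter in either direction. Compound 3 is therefore expected at 44%, between 30% and 58%, a step of a number 3 percentage points lower from compound 2 to compound 3 (within the scatter).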

Compound 3, a percentage reported as inhibition, at one concentration (the size of the read-out at that concentration, not a potency): 92%
For compound 3 the middle estimate is 48 percentage points below the measured one, and the stated range ends below it.
By their numbers in this assay, from the lowest: compounds 1 and 2 (each within the scatter of the next); then compound 3.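

Cyanomethyl in place of cyano on a saturated chain carbon, three bonds along the chain from an oxygen on an aromatic ring, gives a number 45 percentage points higher from compound 2 to compound 3 (beyond the scatter) in this assay, so this position responds strongly to the length of the chain carrying the nitrile. With that chain held as 4-cyanobutyl, vinyl in place of propyl on a saturated chain carbon bound to an aromatic carbon gives a number 51 percentage points higher from compound 1 to compound 3 (beyond the scatter), so this second position also matters. Nothing measured here accounts for either step. On these data alone, it remains open whether a longer chain would hold this level of inhibition, and whether the nitrile could give way to an amine or a carboxylic acid.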